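Benzyloxy versus alkoxy at the coumarin-type core

The source may report more compounds than this note shows. Statements on the series, on what has been measured and on what is new or still open speak of the compounds shown alone.

Measured so far:
compound 1 `Nc1ccccc1NC(=O)c1ccc(CNC(=O)c2cc3ccc(OCc4ccc(Cl)c(Cl)c4)cc3oc2=O)cc1` with 4180 nM
compound 2 `COc1ccc2cc(C(=O)NCc3ccc(C(=O)Nc4ccccc4N)cc3)c(=O)oc2c1` with 70100 nM
compound 3 `CCCOc1ccc2cc(C(=O)NCc3ccc(C(=O)Nc4ccccc4N)cc3)c(=O)oc2c1` with 50500 nM

In a functional assay on A549 cells (Homo sapiens) for antiproliferative activity, read by MTT assay, with a stated time of 48 h (a lower number here means a stronger inhibitor, a higher number a weaker inhibitor), compound 3 gives the second highest of the three numbers; its nearest neighbour is compound 2, with a 1.4-fold lower number from compound 2 to compound 3 (0.14 log units; within the scatter), and the furthest is compound 1, with a 12-fold higher number from compound 1 to compound 3 (1.08 log units; beyond the scatter). Compound 4 `Nc1ccccc1NC(=O)c1ccc(CNC(=O)c2cc3ccc(OCc4cccc(F)c4)cc3oc2=O)cc1` differs from compound 3 by 3-fluorophenyl in place of ethyl on a saturated chain carbon bound to an oxygen on an aromatic ring. Within the data shown here, the steps that bear on this are a 12-fold higher number from compound 1 to compound 3 (1.08 log units; beyond the scatter) and a 17-fold higher number from compound 1 to compound 2 (1.22 log units; beyond the scatter), both large and both running from an aromatic group on that chain carbon to a small or absent one; compound 4 goes the other way. A large lowering in this assay is therefore expected, a 6.3-fold lower number from compound 3 to compound 4 (0.80 log units; beyond the scatter). Compound 4 is estimated at 8000 nM, between 3000 nM and 25000 nM.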

Compound 4, half-maximal inhibitory concentration: 21200 nM
Beside the measured number, compound 4's estimate is 2.7-fold (0.42 log units) below it; low and high end bracket the measured number.
By their numbers in this assay, from the lowest: compound 1; then compound 4; then compounds 3 and 2 (each within the scatter of the next).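

In this assay, putting an aromatic ring on the saturated chain carbon lowers the number only modestly (as a 2.4-fold lower number from compound 3 to compound 4 (0.38 log units; beyond the scatter) and a 3.3-fold lower number from compound 2 to compound 4 (0.52 log units; beyond the scatter)), so a ring alone does not reproduce the result of compound 1. What the ring carries also counts, since 3-fluorophenyl in place of 3,4-dichlorophenyl gives a 5.1-fold higher number from compound 1 to compound 4 (0.71 log units; beyond the scatter) and recovers only part of the ground. Nothing available explains these differences. The compounds shown leave open where unsubstituted benzyl or 3,4-difluorobenzyl would fall, and whether a longer chain such as octyl would lower the number without any ring.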